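Moving a Methyl on a Hydroxamic Acid Series

This account rests on a few compounds, and the source may have more. Where it says the series, first, only, none or still open, it means among the compounds named here.

Measured so far in a functional assay on MGC-803 cells (Homo sapiens) for antiproliferative activity, read by MTT assay, with a stated time of 72 h; on this read-out lower numbers stand for stronger inhibition and higher numbers for weaker inhibition:
compound 1, `Cc1cccc(-c2nc(CNc3ccc(C(=O)NO)cc3)n(-c3ccccc3)n2)c1`, gives 8710 nM.
compound 3, `O=C(NO)c1ccc(NCc2nc(-c3ccccc3)nn2-c2cccc(Cl)c2)cc1`, gives 13700 nM.
compound 2, `O=C(NO)c1ccc(NCc2nc(-c3cccs3)nn2-c2ccc(O)cc2)cc1`, gives only a limit of the assay, > 20000 nM.

Three compounds share a core that carries a hydroxamic acid on one aryl group. Among the two numbers reported in this assay, compound 1 has the lowest; its nearest neighbour is compound 3, whose number is higher but lies within the scatter of the assay, so the two cannot be set in order. The value of compound 2 is a limit, at which one of the three values sits (the limit of > 20000 nM in this assay, at which 1 of the 3 values shown sits).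

Compound 4, `Cc1ccc(-c2nc(CNc3ccc(C(=O)NO)cc3)n(-c3ccccc3)n2)cc1`, has not yet been measured. It is built from the same atoms as compound 1, joined differently: 4-methylphenyl in place of 3-methylphenyl on an aromatic carbon. Among the measured compounds shown here, no pair of measured compounds differs in exactly one place, so there is no measured step of this size to lean on. Compound 4 is expected to stay close to compound 1, and the step of a 1.0-fold higher number from compound 1 to compound 4 (0.01 log units; within the scatter) is estimated to fall within the scatter. Compound 4 is expected to give about 9000 nM, between 4000 nM and 20000 nM.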

Compound 4, half-maximal inhibitory concentration: > 20000 nM
Compound 4: no number, only a limit (the forecaster's own chance of this, stated with the estimate: 20%); middle value at least 2.2-fold (0.34 log units) away from the limit.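

In this assay, among the compounds shown here, 4-methylphenyl in place of 3-methylphenyl gives an at least 2.2-fold higher number from compound 1 to compound 4 (0.36 log units; beyond the scatter), the first step in this set that can be read between compounds differing in one place. It shows that on this aromatic carbon, with the same atoms present and the same counts of heavy atoms, donors and acceptors in the group, how the methyl is joined is enough to carry the read-out beyond the scatter, towards weaker inhibition. Compound 4 gives > 20000 nM, which is a limit of the assay and not a number, and compound 4 shares that limit with compound 2: the limit of > 20000 nM in this assay, at which 2 of the 4 values shown sit.

The compounds shown leave open whether 2-methylphenyl on the same aromatic carbon, or an amine or a carboxylic acid in place of the methyl, would read like compound 1 or like compound 4. For the compounds shown here, they also leave open whether this change would give a step of the same kind with a group other than phenyl on the ring nitrogen, as this is the only pair here that differs in one place.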